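A Larger Side Chain on a Compound at the Solubility Limit

The source may report more compounds than this note shows. Statements on the series, on what has been measured and on what is new or still open speak of the compounds shown alone.

Compound 3 `C=CC(=O)Nc1cccc(-n2c(-c3nc(-c4cnn(C)c4)cnc3N)nc3ccccc32)c1` stands at the floor of a physicochemical assay for solubility, at pH 7.4; a higher number here means a more soluble compound, a lower number a less soluble compound: in this assay compound 3 reports only a limit, < 10000 nM. Compound 1 `C=CC(=O)Nc1cccc(-n2c(-c3nc(-c4cnn(C5CCN(C)CC5)c4)cnc3N)nc3ccccc32)c1` likewise reaches only a limit in this assay, < 10000 nM. Compound 2 `C=CC(=O)Nc1cccc(-n2c(-c3nc(-c4cnn(C5CCN(C)CC5)c4)cnc3N)nc3ccncc32)c1` differs from compound 1 only within the shared core; in this assay compound 2 gives 540000 nM. The single measured step among these, a step that the two limits leave unreadable from compound 1 to compound 3, cannot be read because both of its ends sit at the limit of < 10000 nM in this assay, at which 2 of the 3 values shown sit. Compound 4 `C=CC(=O)Nc1cccc(-n2c(-c3nc(-c4cnn(CCN5CCN(C)CC5)c4)cnc3N)nc3ccccc32)c1` differs from compound 3 by (4-methylpiperazin-1-yl)methyl in place of hydrogen on a saturated chain carbon bound to an aromatic nitrogen. Within the data shown here, no measured step mirrors this change, and the one step that touches the same aromatic nitrogen is unreadable, so the direction of the step to compound 4 cannot be taken from the data; the chain that enters resembles what compound 1 carries more than what compound 3 carries, and compound 1 sits at the limit too. Compound 4 is therefore expected to remain near the limit, at an estimated 6000 nM (between 1000 nM and 30000 nM), an expected step that the limit leaves unreadable from compound 3 to compound 4.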

Compound 4, solubility: 30000 nM
Estimate against measurement, compound 4: 5.0-fold (0.70 log units) below, within the range that was stated.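

In this assay, among these compounds, the aromatic nitrogen now gives a readable change for the first time: 2-(4-methylpiperazin-1-yl)ethyl in place of methyl gives an at least 3.0-fold higher number from compound 3 to compound 4 (0.47 log units; beyond the scatter) and the same group in place of 1-methylpiperidin-4-yl gives an at least 3.0-fold higher number from compound 1 to compound 4 (0.47 log units; beyond the scatter) on the same shared core. This position can therefore move the number, and the two groups that carry a six-membered non-aromatic ring are not interchangeable here. Both sizes are only minimum sizes, and the step that joins compound 1 and compound 3 still cannot be read.

From the compounds shown here alone, it remains open whether a morpholine or a carboxylic acid at the end of the same chain, or a longer chain, would move the number further. Going by these compounds, it is also open how the 2-(4-methylpiperazin-1-yl)ethyl group would behave on the core of compound 2.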